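The compounds below may be only part of what the source reports. "The series", "measured", "known", "first", "only" and "open" are said of these compounds alone.

Measured compounds:
Compound 1, `COc1cc(C2CCN(C[C@@H](C)O)CC2)ccc1Nc1ncc2ccc(-c3ccccc3N(C)S(C)(=O)=O)n2n1`: in an in vitro ADME assay on microsomes from liver (Mus musculus, strain CD1) for metabolic stability, using NADPH, with a stated time of 10 min, tested at 0.5 uM (a higher number here means that the compound lasts longer, a lower number that the compound disappears faster), compound 1 gives > 0.666 h, a limit of the assay rather than a number.
Compound 2, `COc1cc(C2CCNCC2)ccc1Nc1ncc2ccc(-c3ccccc3N(C)S(C)(=O)=O)n2n1`: in this assay compound 2 gives > 0.666 h, likewise a limit of the assay.

Compound 1 stands at the limit of > 0.666 h in this assay, at which 2 of the 2 values shown sit, so no number is known for it, only that limit. Within the data shown here, the single measured step, a step that the two limits leave unreadable from compound 1 to compound 2, is hydrogen in place of 2-hydroxypropyl on an amine nitrogen in a ring, and both of its ends are limits, so its size cannot be read. Compound 3, `COc1cc(C2CCN(C[C@@H](C)O)CC2)ccc1Nc1ncc2ccc(-c3ccccc3OC)n2n1`, differs from compound 1 by methoxy in place of methyl(methylsulfonyl)amino on an aromatic carbon. The measured step touches a different part of the molecule and does not bear on this change, so neither direction nor size of the step in this assay can be read from the data shown. Compound 3 is therefore expected to give about 0.6 h, within 0.2 h to 1.5 h. That estimate means an expected step of an at least 1.1-fold lower number from compound 1 to compound 3 (0.04 log units; that floor lies within the scatter).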

Compound 3, half-life: > 0.666 h
Compound 3: a limit, no number; the forecaster's own chance of this, stated with the estimate: 45%; middle value at least 1.1-fold (0.04 log units) from the limit.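

In this assay compound 3 gives > 0.666 h, a limit of the assay. Compound 1 also stands at a limit, so no new step can be read between compound 1 and compound 3. The compounds shown leave open the actual half-life of each, and whether methoxy in place of methyl(methylsulfonyl)amino changes it, with all values at one limit: the limit of > 0.666 h in this assay, at which 3 of the 3 values shown sit.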